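Thiophene for phenyl on the ester of compound 3

The source may report more compounds than this note shows. Statements on the series, on what has been measured and on what is new or still open speak of the compounds shown alone.

Three compounds have been measured:
compound 1 `COC(=O)c1ccc2c(I)cc(C(=O)c3ccccc3)c-2cc1` — -5.4%
compound 2 `NC(=O)c1ccc2c(C=O)cc(-c3ccccc3)c-2cc1` — 16.7%
compound 3 `O=C(Oc1ccc2ccc(Cl)ccc1-2)c1ccccc1` — 34.3%

In an assay on cells for displacement of a labelled ligand from Orexin receptor type 2 (Homo sapiens), read by scintillation counting, with stated times of 10 min and 90 min, tested at 10 uM (on this read-out lower numbers stand for less inhibition and higher numbers for more inhibition at the one concentration tested (going by the name of the read-out)), compound 3 stands highest of the three numbers. Its nearest neighbour is compound 2, whose value lies lower by an amount beyond the scatter, and compound 1 lies lower still, also beyond the scatter. For the measured compounds named here, no two of the measured compounds differ in only one place, so no single step between them can be traced.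

Compound 4 `O=C(Oc1ccc2ccc(Cl)ccc1-2)c1cccs1` is not yet measured. It differs from compound 3 by one change: thiophen-2-yl in place of phenyl on a carbonyl carbon. Going by the values given here, with no measured pair that isolates this kind of swap, nothing among the three compounds points to a direction for it. The step in this assay from compound 3 to compound 4 is therefore expected to be small, a number 4.3 percentage points lower from compound 3 to compound 4 (within the scatter), and not beyond the scatter in either direction. Compound 4 is estimated to give 30%, within a range from 8% to 52%.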

Compound 4, a percentage reported as inhibition, at one concentration (the size of the read-out at that concentration, not a potency): 33.2%
The estimate for compound 4 lay 3.2 percentage points below the measured number; low and high end bracket the measured number.
By their numbers in this assay, from the lowest: compound 1; then compound 2; then compounds 4 and 3 (each within the scatter of the next).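

For the compounds shown here, replacing phenyl with thiophen-2-yl on a carbonyl carbon gives the first step that can be read in this assay, and it is a number 1.1 percentage points lower from compound 3 to compound 4 (within the scatter). At this position, then, a five-membered aromatic ring with one sulfur atom and a six-membered aromatic ring of carbon only give numbers that this read-out cannot tell apart, so this one swap neither gains nor loses measurable inhibition. No measurement at hand offers a reason for this.

One swap between two aromatic rings does not show whether the number in this assay would be higher, lower or level after other changes at this position, and a ring bearing an amine or a carboxylic acid could behave differently. On these data alone, the role of the ester oxygen also stays open, as an amide linkage in its place would be needed to test it.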